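Chlorophenyl Carbonyl in Place of Cyclohexyl on the Amide Tail

A few compounds are considered here, and "the series" means these few. Any claim that something is new, unique, unknown or untested is made for them only; others in the source may bear on it.

Measured so far:
Compound 1 `CC(C)C[C@H](N)c1cc(C(F)(F)F)ccc1N1CCN(C(=O)COc2ccc3ccccc3c2)CC1` gives 2000 nM in an assay on HEK293 cells for displacement of a labelled ligand from Melanocortin receptor 4 (Homo sapiens); a lower number here means a stronger inhibitor, a higher number a weaker inhibitor.
Compound 2 `CC(C)C[C@H](N)c1cc(C(F)(F)F)ccc1N1CCN(C(=O)CCC2CCCCC2)CC1` gives 5700 nM in this assay.

For the measured compounds named here, compound 2 holds the highest of the two numbers; the only step known, a 2.9-fold higher number from compound 1 to compound 2 (0.45 log units; beyond the scatter), separates it from compound 1. Compound 3 `CC(C)C[C@H](N)c1cc(C(F)(F)F)ccc1N1CCN(C(=O)CCC(=O)c2ccc(Cl)cc2)CC1` differs from compound 2 by (4-chlorophenyl)carbonyl in place of cyclohexyl on a saturated chain carbon, two bonds along the chain from a carbonyl carbon. Going by the values given here, the one measured step concerns a different exchange at the same chain, so it bears only loosely here; it shows that a six-membered aromatic ring of carbon only in that region gave the lower number of the two. Compound 3 is therefore expected to give a modestly lower number, a 1.9-fold lower number from compound 2 to compound 3 (0.28 log units; within the scatter), with an estimate of 3000 nM in this assay, within 1000 nM to 10000 nM.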

Compound 3, inhibition constant: 820 nM
Beside the measured number, compound 3's estimate is 3.7-fold (0.56 log units) above it; the whole stated range lies above it.
By their numbers in this assay, from the lowest: compound 3; then compound 1; then compound 2.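

In this assay the chain tolerates a larger, carbonyl-bearing tail: (4-chlorophenyl)carbonyl in place of cyclohexyl gives a 7.0-fold lower number from compound 2 to compound 3 (0.84 log units; beyond the scatter). The same tail, read as ((4-chlorophenyl)carbonyl)methyl in place of (naphthalen-2-yl)oxy, gives a 2.4-fold lower number from compound 1 to compound 3 (0.39 log units; beyond the scatter), which makes compound 3 the strongest of the three. Nothing available explains these steps. On these data alone, the ring, carbonyl and chlorine entered together, so their separate shares remain unknown. An unsubstituted phenylcarbonyl or a 4-chlorophenyl on the chain without the carbonyl would separate them.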